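Pyrrolidine for methyl on a piperidine bis-amide cytotoxicity series

The compounds below may be only part of what the source reports. "The series", "measured", "known", "first", "only" and "open" are said of these compounds alone.

The measured compounds and their values:
Compound 1, `O=C(Nc1ccc(Cl)cn1)C1CCCN(C(=O)c2cc(C(F)(F)F)cc(C(F)(F)F)c2)C1`, gives 0%.
Compound 2, `C=Cc1cccc(C(=O)N2CCCC(C(=O)Nc3ccc(Cl)cc3)C2)c1`, gives 0%.
Compound 3, `CCc1cccc(NC(=O)C2CCCN(C(=O)c3cc(C(F)(F)F)cc(C(F)(F)F)c3)C2)c1`, gives 0%.

All three share a piperidine core carrying two amide groups, and all three were tested in an ADME assay on PC-3 cells (Homo sapiens) for cytotoxicity, read by WST assay, tested at 100 uM; a higher number here means more inhibition at the concentration tested (going by the name of the read-out), a lower number less inhibition. Compound 3 stands level with compound 1 and compound 2 at the digits shown; none of the three produces any inhibition beyond the usual scatter.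

Compound 4, `O=C(Nc1cccc(CN2CCCC2)c1)C1CCCN(C(=O)c2cc(C(F)(F)F)cc(C(F)(F)F)c2)C1`, has not yet been measured. It differs from compound 3 in one place: pyrrolidin-1-yl in place of methyl on a saturated chain carbon bound to an aromatic carbon.

Going by the values given here, the one measured step that bears on this is the exchange of the aromatic group on the amide nitrogen, which gave no change at the digits printed from compound 1 to compound 3 (within the scatter). Compound 2 and compound 3, which differ in more than one place, also show the same reading in this assay. Nothing in the measured set shows a change on this side of the molecule moving the read-out.

Compound 4 is therefore expected to show a number 5 percentage points higher from compound 3 to compound 4 (within the scatter), and its value is estimated at 5%, within a range from 0% to 25%.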

Compound 4, a percentage reported as inhibition, at one concentration (the size of the read-out at that concentration, not a potency): 51%
Compound 4: middle estimate off by 46 percentage points, on the low side; measured number above the stated range.
By their numbers in this assay, from the lowest: compounds 1, 2 and 3 (each within the scatter of the next); then compound 4.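

In this assay, going by these compounds alone, pyrrolidin-1-yl in place of methyl on a saturated chain carbon bound to an aromatic carbon gives a number 51 percentage points higher from compound 3 to compound 4 (beyond the scatter), so this position is not silent, as the flat readings of the earlier compounds might have suggested. The same holds when compound 4 is set against compound 1: 3-((pyrrolidin-1-yl)methyl)phenyl in place of 5-chloropyridin-2-yl on an amide-type nitrogen gives a number 51 percentage points higher from compound 1 to compound 4 (beyond the scatter), whereas 3-ethylphenyl at that nitrogen gave no change at the digits printed from compound 1 to compound 3 (within the scatter), so the read-out depends on what this aromatic group carries and not merely on swapping one aromatic group for another. No measurement shown here explains the size of this jump.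

The compounds shown leave open whether the ring nitrogen or the ring as a whole goes with the higher reading, which a cyclopentyl group, with carbon in place of that nitrogen, or an open-chain dimethylamino group at the same carbon could help separate. They also leave open whether the effect survives when the bis(trifluoromethyl)benzoyl group on the other amide is exchanged, for example for the 3-vinylbenzoyl group of compound 2.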